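The source may hold more compounds than are shown below. What is called first, only, known or untested is meant among the compounds shown, and "the series" means these compounds.

Measured so far in a physicochemical assay for solubility, using the shake flask method, with a stated time of 12 h; on this read-out lower numbers stand for lower solubility and higher numbers for higher solubility:
- compound 1 `O=C(/C=C/c1ccccc1O)/C=C/c1cccc(O)c1O`: 151000 nM
- compound 2 `O=C(/C=C/c1ccccc1O)CC(=O)c1ccc(O)c(O)c1`: 77000 nM

Only these two numbers are available, and compound 2 at 77000 nM lies within the scatter of compound 1 at 151000 nM. The next compound to be measured is compound 3 `O=C(/C=C/c1cccc(O)c1)CC(=O)c1ccc(O)c(O)c1`, which has the same atoms as compound 2, joined differently: 3-hydroxyphenyl in place of 2-hydroxyphenyl on a double-bonded chain carbon bound to a double-bonded chain carbon. The change places 3-hydroxyphenyl in place of 2-hydroxyphenyl on a double-bonded chain carbon bound to a double-bonded chain carbon. Among the compounds with values here, no measured pair isolates this change, so the expectation rests on compound 2 at 77000 nM and on the narrow spread of the two known numbers. The expected step, a 1.1-fold lower number from compound 2 to compound 3 (0.04 log units; within the scatter), is none beyond the scatter in this assay. For compound 3 the estimated value is 70000 nM, with an expected range of 30000 nM to 160000 nM.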

Compound 3, solubility: 25000 nM
Compound 3: the middle estimate sits 2.8-fold (0.45 log units) above what was measured; the whole stated range lies above it.
By their numbers in this assay, from the lowest: compound 3; then compounds 2 and 1 (each within the scatter of the next).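

In this assay, 3-hydroxyphenyl in place of 2-hydroxyphenyl on a double-bonded chain carbon bound to a double-bonded chain carbon gives a 3.1-fold lower number from compound 2 to compound 3 (0.49 log units; beyond the scatter) and so shows that this place responds to how the hydroxyphenyl is joined, although both groups have the same heavy-atom, donor and acceptor counts. Compound 1 and compound 2 could not show this, as they differ in more than one place and their values lie within the scatter of each other. No measurement at hand accounts for the step.

On these data alone, with a single pair at this place, it remains open whether the same change gives a similar step on the core of compound 1. Also open, as far as these compounds go, is how this assay would read with an amine or a carboxylic acid on the phenyl ring at this place.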